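The source may hold more compounds than are shown below. What is called first, only, known or untested is meant among the compounds shown, and "the series" means these compounds.

Measured compounds:
compound 1 `COc1cc(C2CCN(C[C@@H](C)O)CC2)ccc1Nc1ncc2ccc(-c3ccccc3OC)n2n1`, giving 0.35 h
compound 2 `COc1cc(C2CCN(CC(N)=O)CC2)ccc1Nc1ncc2c(O)cc(-c3ccccc3N(C)S(C)(=O)=O)n2n1`, giving < 0.0834 h

In an in vitro ADME assay on microsomes from liver (Macaca mulatta) for metabolic stability, using NADPH, with a stated time of 10 min, tested at 0.5 uM (on this read-out lower numbers stand for a shorter-lived compound and higher numbers for a longer-lived compound), compound 1 gives 0.35 h. Compound 2 stands differently: its result of < 0.0834 h is a limit of the assay, not a number, so where it lies below that boundary is not known. This is the point noted as the limit of < 0.0834 h in this assay, at which 1 of the 2 values shown sits, at which one of the two values shown sits.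

Compound 3 `COc1cc(C2CCN(CC(N)=O)CC2)ccc1Nc1ncc2c(Cl)cc(-c3ccccc3N(C)S(C)(=O)=O)n2n1` is not yet measured. It differs from compound 2 by chloro in place of hydroxy on an aromatic carbon. Among the compounds with values here, no step between two measured compounds is available to set a scale for this change, and the starting point is itself only a limit. The step from compound 2 to compound 3 is therefore expected to be an at least 1.4-fold higher number from compound 2 to compound 3 (0.15 log units; that floor lies within the scatter), with no firm direction that the data can support. Compound 3 is estimated at 0.12 h in this assay, within a range from 0.04 h to 0.4 h.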

Compound 3, half-life: 0.25 h
The estimate for compound 3 lay 2.1-fold (0.32 log units) below the measured number; the measured number falls inside the stated range.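

In this assay, within the data shown here, chloro in place of hydroxy on the aromatic carbon two ring bonds from the ring nitrogen gives an at least 2.9-fold higher number from compound 2 to compound 3 (0.47 log units; beyond the scatter); this is the first step between measured compounds that differ in one place, and it shows that this position can move the half-life beyond the scatter. Compound 2 gives < 0.0834 h, which is a limit of the assay and not a number. The full size of the step stays unknown because it starts from that limit: the limit of < 0.0834 h in this assay, at which 1 of the 3 values shown sits.

The compounds shown do not tell whether the higher number goes with chloro itself or with the loss of hydroxy, a question on which a fluoro or a nitrile at this position would bear. From the compounds shown here alone, whether the step holds with other groups elsewhere on the shared core also remains open.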